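Methoxy for chloro on a second core: growth inhibition expected

This account rests on a few compounds, and the source may have more. Where it says the series, first, only, none or still open, it means among the compounds named here.

Three compounds have been measured in a functional assay on SK-MEL-5 cells (Homo sapiens); a lower number here means a stronger inhibitor of growth, a higher number a weaker inhibitor of growth:
compound 1 `Cc1cc(C)c2c(O)cc(-c3ccc(Cl)cc3)nc2n1`: 14100 nM
compound 2 `COc1ccc(-c2cc(O)c3c(C)cc(C)nc3n2)cc1`: 17800 nM
compound 3 `Cc1cnc2nc(-c3ccc(Cl)cc3)cc(O)c2c1`: 2190 nM

Compound 1 and compound 2 share a core and differ in one place, (methoxy in place of chloro on an aromatic carbon). That change gave a 1.3-fold higher number from compound 1 to compound 2 (0.10 log units; within the scatter). Compound 3 carries a different core; the difference between the two cores is not broken down here, but in this assay compound 3 gives the lowest of the three numbers, and its gap to compound 1 and to compound 2 lies beyond the scatter.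

Compound 4 `COc1ccc(-c2cc(O)c3cc(C)cnc3n2)cc1` is not yet measured. It differs from compound 3 by methoxy in place of chloro on an aromatic carbon, the same change as between compound 1 and compound 2, at the same place. Because a 1.3-fold higher number from compound 1 to compound 2 (0.10 log units; within the scatter) lay within the scatter, a small step, a 1.3-fold higher number from compound 3 to compound 4 (0.11 log units; within the scatter), is expected here too. Compound 4 is thus estimated at 2800 nM, between 1200 nM and 7000 nM.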

Compound 4, concentration for 50% growth inhibition: 3720 nM
Compound 4: the middle estimate sits 1.3-fold (0.12 log units) below what was measured, within the range that was stated.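

In this assay, methoxy in place of chloro on an aromatic carbon gave a 1.7-fold higher number from compound 3 to compound 4 (0.23 log units; within the scatter). Set beside the earlier step, the change carries across the two cores with no difference that can be told from the scatter: the same change on two cores in this assay, a 1.3-fold higher number (0.10 log units; within the scatter) from compound 1 to compound 2 and a 1.7-fold higher number (0.23 log units; within the scatter) from compound 3 to compound 4, 1.3-fold (0.13 log units) apart, within the scatter of two such steps. Among these compounds, this rests on only two pairs and one change at one place, so it shows that the swap stayed small on these two cores, not that it would stay small on any other core.

The compounds shown leave open whether a different group at that place, such as an amine or a carboxylic acid, would give a step beyond the scatter. They also leave open how the same change would behave on a third core.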